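From compound 2 to compound 4 at the assay limit

A few compounds are considered here, and "the series" means these few. Any claim that something is new, unique, unknown or untested is made for them only; others in the source may bear on it.

Values in an ADME assay on HEK293 cells (Homo sapiens) for cytotoxicity, read by reporter gene assay and resazurin assay, with a stated time of 48 h (a lower number here means that less compound is tolerated, a higher number that more compound is tolerated), stand as follows:
- Compound 1 `COc1c(Br)cc(Br)cc1C(=O)Nc1ccccc1` gives > 100000 nM as a limit
- Compound 2 `O=C(Nc1ccc(Sc2nc3ccccc3s2)c(Cl)c1)c1cc(Br)cc(Br)c1` gives > 100000 nM as a limit
- Compound 3 `O=C(Nc1ccc(Sc2nc3ccccc3s2)cc1)c1cc(Br)cc(Br)c1` gives > 100000 nM as a limit
- Compound 4 `COc1c(Br)cc(Br)cc1C(=O)Nc1ccc(Sc2nc3ccccc3s2)c(Cl)c1` has not yet been measured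

Compound 2 sits at > 100000 nM as a limit and not a number. It therefore has no exact place among the measured compounds, which share the limit of > 100000 nM in this assay, at which 3 of the 3 values shown sit, and offer no readable scale.

Going to compound 4 brings methoxy in place of hydrogen on an aromatic carbon and leaves the rest of compound 2 unchanged. The methoxy enters ortho to a bromo group and para to a bromo group.

Going by the values given here, the only measured step is a step that the two limits leave unreadable from compound 2 to compound 3 and it concerns hydrogen in place of chloro, so it gives no size to carry over. Closer in structure is compound 1, which also carries a methoxy and gives > 100000 nM as a limit. On this basis, no step beyond the scatter is expected in this assay in either direction. The expected step is a number no higher from compound 2 to compound 4 (the limit leaves the size open) by this estimate. Compound 4 is estimated at 100000 nM with an expected range from 40000 nM to 200000 nM and will most likely be reported as a limit again.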

Compound 4, half-maximal cytotoxic concentration: > 100000 nM
Compound 4 ended at the assay's limit; the forecaster's own chance of this, stated with the estimate: 85%; the middle value lies on the limit itself.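

In this assay compound 4 gives > 100000 nM, a limit and not a number. No step can be read between compound 2 and compound 4 because both sit at the same limit: the limit of > 100000 nM in this assay, at which 4 of the 4 values shown sit.

The compounds shown leave open what concentration of any of them is cytotoxic, and whether methoxy in place of hydrogen changes it.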